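This account rests on a few compounds, and the source may have more. Where it says the series, first, only, none or still open, it means among the compounds named here.

Working notes on the series. In an ADME assay on L929 cells (Mus musculus) for cytotoxicity, read by resazurin assay, with a stated time of 48 h (a higher number here means that more compound is tolerated, a lower number that less compound is tolerated), compound 1 (`COC(=O)CCn1c2ccc([N+](=O)[O-])cc2c(=O)n1Cc1ccccc1`) gives > 256000 nM, which is a limit of the assay and not a number. Compound 2 (`O=C(O)CCn1c2ccc([N+](=O)[O-])cc2c(=O)n1Cc1ccccc1`) gives > 256000 nM, also a limit. Compound 3 (`CCOC(=O)CCCn1c2ccc([N+](=O)[O-])cc2c(=O)n1Cc1ccccc1`) gives a number, 78100 nM. Compound 1 therefore stands at the limit of > 256000 nM in this assay, at which 2 of the 3 values shown sit, with no exact position of its own.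

Compound 4 (`O=c1c2cc([N+](=O)[O-])ccc2n(CCO)n1Cc1ccccc1`) differs from compound 1 by hydroxy in place of methoxycarbonyl on a saturated chain carbon, two bonds along the chain from an aromatic nitrogen. Among the measured compounds shown here, none of the measured steps makes this exact change, though three alter the same chain. The first, a step that the two limits leave unreadable from compound 1 to compound 2, gives no size. The other two are an at least 3.2-fold lower number from compound 1 to compound 3 (0.51 log units; beyond the scatter) and an at least 3.2-fold lower number from compound 2 to compound 3 (0.51 log units; beyond the scatter), and both came with (ethoxycarbonyl)methyl, a group that compound 4 does not carry.

With only compound 3 reading a number in this assay, no step beyond the scatter is expected here, and any movement is expected toward a lower number. The expected step is an at least 1.1-fold lower number from compound 1 to compound 4 (0.04 log units; that floor lies within the scatter). For compound 4 the estimated value is 230000 nM, with an expected range of 100000 nM to 500000 nM.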

Compound 4, concentration lethal to 50% of the cells: > 256000 nM
Compound 4: no number, only a limit; the forecaster's own chance of this, stated with the estimate: 60%; middle value at least 1.1-fold (0.04 log units) away from the limit.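

Compound 4 adds hydroxy to methoxycarbonyl and carboxy as a third group on a saturated chain carbon, two bonds along the chain from an aromatic nitrogen, that leaves the read-out in this assay at a limit and not at a number: the limit of > 256000 nM in this assay, at which 3 of the 4 values shown sit. The change from (ethoxycarbonyl)methyl to hydroxy gives an at least 3.2-fold higher number from compound 3 to compound 4 (0.51 log units; beyond the scatter), which leaves (ethoxycarbonyl)methyl as the only group shown at this place that brings a number at all. The steps from compound 1 to compound 4 and from compound 2 to compound 4 cannot be read, since both ends of each are limits, so no order among methoxycarbonyl, carboxy and hydroxy can be stated.

On these data alone, what stays open is whether the number of compound 3 follows the longer chain or the ethyl ester, as (ethoxycarbonyl)methyl differs from the other groups in both. A longer chain ending in hydroxy or in a carboxylic acid, or an amine at the same place, would show whether any group other than that ester brings the read-out off the limit.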